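The source may report more compounds than this note shows. Statements on the series, on what has been measured and on what is new or still open speak of the compounds shown alone.

Measured so far:
compound 1 `CC(C)(C)c1cc(NC(=O)Nc2ccc(Nc3ncnc4c3OCCN4)c(F)c2)no1` — 22 nM
compound 2 `COc1cc(NC(=O)Nc2cc(C(C)(C)C)on2)ccc1Nc1ncnc2c1OCCN2` — 33 nM

Both numbers come from an assay on isolated protein for inhibition of proto-oncogene tyrosine-protein kinase receptor Ret variant V804M (Homo sapiens), read by 33P incorporation, with stated times of 15 min and 40 min; on this read-out lower numbers stand for stronger inhibition and higher numbers for weaker inhibition. In this assay, among the compounds with values here, compound 1 gives 22 nM and compound 2 gives 33 nM; the single step between them, a 1.5-fold higher number from compound 1 to compound 2 (0.18 log units; within the scatter), lies within the scatter, so compound 2 stands level with compound 1 and neither can be ranked against the other.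

Compound 3 `CC(C)(C)c1cc(NC(=O)Nc2ccc(Nc3ncnc4c3OCCN4)c(O)c2)no1` is not yet measured. It differs from compound 2 by hydrogen in place of methyl on an oxygen on an aromatic ring, that is methoxy to hydroxy. Within the data shown here, no measured step touches this oxygen; the nearest comparison is a 1.5-fold higher number from compound 1 to compound 2 (0.18 log units; within the scatter), which exchanged fluoro for methoxy on an aromatic carbon without moving the number beyond the scatter. Fluoro and methoxy thus gave near-identical results, and hydroxy is expected to do the same. No step beyond the scatter is expected for the change from compound 2 to compound 3, a 1.1-fold lower number from compound 2 to compound 3 (0.04 log units; within the scatter). For compound 3 the estimate in this assay is 30 nM, with a range from 10 nM to 90 nM.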

Compound 3, half-maximal inhibitory concentration: 63 nM
For compound 3 the middle estimate is 2.1-fold (0.32 log units) below the measured one; the measured number falls inside the stated range.
By their numbers in this assay, from the lowest: compounds 1, 2 and 3 (each within the scatter of the next, the first and the last beyond it).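

In this assay, hydrogen in place of methyl on the oxygen on the aromatic ring gives a 1.9-fold higher number from compound 2 to compound 3 (0.28 log units; within the scatter) and so does not separate hydroxy from methoxy. Hydroxy in place of fluoro on the aromatic carbon gives a 2.9-fold higher number from compound 1 to compound 3 (0.46 log units; beyond the scatter) and is the first step at this position to clear the scatter, a modest one, which shows that the position is not wholly indifferent to the group it carries, although methoxy still cannot be ranked against either neighbour. Nothing available explains the difference between fluoro and hydroxy.

The three groups leave open whether the modest loss from fluoro to hydroxy belongs to hydroxy alone or extends to other groups on this carbon. An amine or a chlorine atom at this place would test that, and an ethoxy group would extend the comparison with methoxy.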